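Chloro-Dimethoxyphenyl Variant of a Weak Antiproliferative Core

The source may report more compounds than this note shows. Statements on the series, on what has been measured and on what is new or still open speak of the compounds shown alone.

Compound 1 `COc1ccc(OC)c(-n2nncc2CN2C(=O)C3(C(C#N)=C(N)Oc4c(N)cc5nc6ccccc6nc5c43)c3ccccc32)c1` gives 45100 nM in a functional assay on HepG2 cells (Homo sapiens) for antiproliferative activity, read by MTT assay, with a stated time of 48 h; a higher number here means a weaker inhibitor, a lower number a stronger inhibitor.
Compound 2 `Cc1ccc(-n2nncc2CN2C(=O)C3(C(C#N)=C(N)Oc4c(N)cc5nc6ccccc6nc5c43)c3ccccc32)cc1Cl` gives > 50000 nM in this assay, and that value is a limit of the assay, not a number.

Compound 2 therefore stands at the weak end of what this assay can report; its true value is only bounded, as the line the limit of > 50000 nM in this assay, at which 1 of the 2 values shown sits, shows. For the measured compounds named here, the one measured step, an at least 1.1-fold higher number from compound 1 to compound 2 (0.04 log units; that floor lies within the scatter), is bounded too and lies within the scatter, so the two aryl groups on the triazole nitrogen look alike in this assay.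

Compound 3 `COc1cc(-n2nncc2CN2C(=O)C3(C(C#N)=C(N)Oc4c(N)cc5nc6ccccc6nc5c43)c3ccccc32)c(OC)cc1Cl` carries the change (4-chloro-2,5-dimethoxyphenyl in place of 3-chloro-4-methylphenyl on an aromatic nitrogen). This brings back the two methoxy groups of compound 1 and keeps a chlorine, so the new group is a mixture of the two groups already seen. Both measured values sit near the ceiling of this assay, and the measured step between them is within the scatter, so no step beyond the scatter is expected for a number no higher from compound 2 to compound 3 (the limit leaves the size open). Compound 3 is expected to give about 50000 nM, within 25000 nM to 100000 nM, with a real chance that this assay again reports only a limit.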

Compound 3, half-maximal inhibitory concentration: > 50000 nM
Compound 3: no number, only a limit; the forecaster's own chance of this, stated with the estimate: 55%; the middle value lies on the limit itself.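

Placing chloro where hydrogen stood on an aromatic carbon of the 2,5-dimethoxyphenyl group gives an at least 1.1-fold higher number from compound 1 to compound 3 (0.04 log units; that floor lies within the scatter) and so shows no effect that can be told apart from ordinary assay scatter, although the true size of this step remains open. Compound 2 and compound 3 both give limits, not numbers, so the step between them cannot be read, and swapping 3-chloro-4-methylphenyl for 4-chloro-2,5-dimethoxyphenyl on this aromatic nitrogen yields no measurable comparison. With compound 3, the limit of this assay now holds most of the series, which makes it the main constraint on reading this position: the limit of > 50000 nM in this assay, at which 2 of the 3 values shown sit.

The compounds shown leave open whether any other group on this aromatic nitrogen could bring the value well clear of that limit, such as a phenyl ring carrying an amine or a carboxylic acid, or a longer alkyl chain in place of the phenyl ring. They also leave open how much weaker compound 2 and compound 3 really are, since neither has a measured number in this assay to compare.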